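The source may report more compounds than this note shows. Statements on the series, on what has been measured and on what is new or still open speak of the compounds shown alone.

Measured so far:
compound 1 `CCc1ccccc1NS(=O)(=O)c1cccc(NC(=O)NCCCCl)c1`: > 200000 nM
compound 2 `CCCc1ccccc1NS(=O)(=O)c1cccc(NC(=O)NCCCCl)c1`: 23000 nM
compound 3 `CCNC(=O)Nc1ccc(S(=O)(=O)Oc2ccccc2C)cc1`: 3100 nM

In a functional assay on M21 cells (Homo sapiens) for cytotoxicity, read by sulforhodamine B assay, with a stated time of 48 h (on this read-out higher numbers stand for weaker inhibition and lower numbers for stronger inhibition), compound 1 gives only a limit, > 200000 nM, which is the limit of > 200000 nM in this assay, at which 1 of the 3 values shown sits. Compound 2 gives 23000 nM, and compound 3 gives 3100 nM, the lowest of the two numbers. The change methyl in place of hydrogen on a saturated chain carbon, two bonds along the chain from an aromatic carbon brought an at least 8.6-fold lower number from compound 1 to compound 2 (0.93 log units; beyond the scatter). How the core of compound 1 and the core of compound 3 differ is not broken down here. Compound 4 `CCNC(=O)Nc1ccc(S(=O)(=O)Oc2ccccc2CC)cc1` is not yet measured in this assay ; it differs from compound 3 by methyl in place of hydrogen on a saturated chain carbon bound to an aromatic carbon. This is the same kind of change as from compound 1 to compound 2, but the place differs: there the methyl enters two bonds along the chain from an aromatic carbon, here on a saturated chain carbon bound to an aromatic carbon. Since the earlier step rests on a limit, the expected step is smaller, a 2.1-fold lower number from compound 3 to compound 4 (0.32 log units; beyond the scatter). Compound 4 is therefore estimated at 1500 nM, between 500 nM and 6000 nM.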

Compound 4, half-maximal inhibitory concentration: 2500 nM
For compound 4 the middle estimate is 1.7-fold (0.22 log units) below the measured one; measured number inside the range.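

In this assay, methyl in place of hydrogen on a saturated chain carbon bound to an aromatic carbon gives a 1.2-fold lower number from compound 3 to compound 4 (0.09 log units; within the scatter), so 2-methylphenyl to 2-ethylphenyl makes no readable difference on this core. Carried to another core and another place on the chain, the change does not keep its size: the same change on two cores in this assay, an at least 8.6-fold lower number (0.93 log units; beyond the scatter) from compound 1 to compound 2 and a 1.2-fold lower number (0.09 log units; within the scatter) from compound 3 to compound 4, at least 7.0-fold (0.84 log units) apart, beyond the scatter of two such steps Core and place differ together between these two steps, so the gap does not show which of the two accounts for it.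

Still open, going by these compounds, is whether 2-propylphenyl on the core of compound 3 would give a step like the one seen on the core of compound 1. A longer chain such as butyl, or an amine at the end of that chain, also remains untested among the compounds shown.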